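Swapping the Piperidine Ring for an Open Hydroxy Chain

This account rests on a few compounds, and the source may have more. Where it says the series, first, only, none or still open, it means among the compounds named here.

Measured compounds in an assay on HEK293T cells for displacement of a labelled ligand from Leucine-rich repeat serine/threonine-protein kinase 2 (Homo sapiens), read by NanoBRET, with a stated time of 2 h; a lower number here means a stronger inhibitor, a higher number a weaker inhibitor:
compound 1 `OC1CCN(c2ncnc3[nH]cc(-c4cccc(Cl)c4)c23)CC1` gives 1340 nM
compound 2 `CNC1CCN(c2ncnc3[nH]cc(-c4cccc(Cl)c4)c23)CC1` gives 3540 nM
compound 3 `Clc1cccc(-c2c[nH]c3ncnc(N4CCCCC4)c23)c1` gives 1140 nM

Compound 3 shows the lowest number of the three, but its separation from compound 1 is a 1.2-fold lower number from compound 1 to compound 3 (0.07 log units; within the scatter), which is within the scatter, so these two cannot be ranked. Only compound 2 stands apart, giving a weaker result: a 3.1-fold lower number from compound 2 to compound 3 (0.49 log units; beyond the scatter).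

Compound 4 `CC(CO)CN(C)c1ncnc2[nH]cc(-c3cccc(Cl)c3)c12` differs from compound 3 in one place: a group of 7 heavy atoms (5 carbon, 1 nitrogen, 1 oxygen; no ring) in place of a group of 6 heavy atoms (5 carbon, 1 nitrogen; one six-membered non-aromatic ring with 1 hetero atom), on an aromatic carbon. The measured steps all keep the piperidin-1-yl ring and vary only a substituent on it. Adding hydroxy there changed little, a 1.2-fold lower number from compound 1 to compound 3 (0.07 log units; within the scatter), while methylamino cost a modest amount, a 2.6-fold higher number from compound 1 to compound 2 (0.42 log units; beyond the scatter). None of them tests removal of the ring itself, so that part of the change is uncharted.

Given this, a modest weakening is expected for compound 4 in this assay, a 1.8-fold higher number from compound 3 to compound 4 (0.24 log units; within the scatter). The estimate for compound 4 is 2000 nM, with a range from 700 nM to 6000 nM.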

Compound 4, half-maximal inhibitory concentration: 7140 nM
Beside the measured number, compound 4's estimate is 3.6-fold (0.55 log units) below it; measured number above the stated range.
By their numbers in this assay, from the lowest: compounds 3 and 1 (each within the scatter of the next); then compounds 2 and 4 (each within the scatter of the next).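

In this assay, among these compounds, compound 4 is the first test of the ring itself, and removing it matters more than the substituent changes did. Compound 1 and compound 4 carry groups with the same heavy atoms, one closed into a six-membered ring and the other open, yet the change gives a 5.3-fold higher number from compound 1 to compound 4 (0.73 log units; beyond the scatter); against the unsubstituted piperidin-1-yl group, the change gives a 6.3-fold higher number from compound 3 to compound 4 (0.80 log units; beyond the scatter). The open chain does not separate from the methylamino-bearing ring, with a 2.0-fold higher number from compound 2 to compound 4 (0.30 log units; within the scatter), so these two cannot be ranked.

The compounds shown do not separate the opening of the ring from the particular features of this chain, which a simple dimethylamino group, a longer chain or an open chain ending in an amine could help to address. Nothing available explains the loss seen on opening the ring.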